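The compounds below may be only part of what the source reports. "The series", "measured", "known", "first", "only" and "open" are said of these compounds alone.

Measured in an ADME assay on MT4 cells (Homo sapiens) for cytotoxicity, read by XTT assay, with a stated time of 5 days (on this read-out lower numbers stand for higher toxicity in this test and higher numbers for lower toxicity in this test), as follows
compound 1 `COC(=O)N[C@H](C(=O)NN(CCC[C@@](O)(Cc1ccccc1)C(=O)N[C@H](CO)C(C)(C)C)Cc1ccc(Br)cc1)C(C)(C)C` gives > 10000 nM
compound 2 `CNC(=O)[C@@H](NC(=O)[C@@](CCCN(Cc1ccc(Br)cc1)NC(=O)[C@@H](NC(=O)OC)C(C)(C)C)(Cc1ccccc1)[Si](C)(C)C(C)(C)C)C(C)(C)C` gives > 10000 nM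
compound 3 `CNC(=O)[C@@H](NC(=O)[C@@](O)(CCCN(Cc1ccc(-c2ccncc2)cc1)NC(=O)[C@@H](NC(=O)OC)C(C)(C)C)Cc1ccccc1)C(C)(C)C` gives > 50000 nM

Each of these three entries is a limit of the assay and not a number. Compound 3 stands at the limit of > 50000 nM in this assay, at which 1 of the 3 values shown sits, and so has no number to start from. Compounds 1 and 2 stand at the limit of > 10000 nM in this assay, at which 2 of the 3 values shown sit, and add no number either.

Compound 4 `CNC(=O)[C@@H](NC(=O)[C@@](O)(CCCN(Cc1ccc(-c2ccccn2)cc1)NC(=O)[C@@H](NC(=O)OC)C(C)(C)C)Cc1ccccc1)C(C)(C)C` has pyridin-2-yl in place of pyridin-4-yl on an aromatic carbon, para to a large group, with the rest of compound 3 unchanged (pyridin-2-yl in place of pyridin-4-yl on an aromatic carbon). The two have the same atoms, joined differently. For the measured compounds named here, no measured pair shows a step for this change, so the expectation rests on the limit of compound 3 alone. The expected step (a number no higher from compound 3 to compound 4 (the limit leaves the size open)) lies within the usual scatter, with no direction favoured. In this assay compound 4 is estimated at 50000 nM, with an expected range of 20000 nM to 100000 nM, and a report as a limit only is the likeliest outcome.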

Compound 4, half-maximal cytotoxic concentration: > 50000 nM
Compound 4: a limit, no number; the forecaster's own chance of this, stated with the estimate: 85%; the middle value sits exactly at the limit.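

No step can be read from compound 3 to compound 4 in this assay: both entries are limits of the assay and not numbers. The compounds shown leave open whether pyridin-2-yl and pyridin-4-yl differ at all on this read-out.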